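Phenyl in place of isopropyl: an untested step

The source may report more compounds than this note shows. Statements on the series, on what has been measured and on what is new or still open speak of the compounds shown alone.

Compound 1 `CCC(C)C1NC(=O)N(C2CCCC2)C1=O` is the starting point of this small set. In a functional assay on MOLT-4 cells (Homo sapiens) for inhibition (a lower number here means a stronger inhibitor, a higher number a weaker inhibitor), compound 1 reaches only a limit, > 200000 nM. Compound 2 `CC(C)C1NC(=O)N(C2CCCC2)C1=O` likewise gives only a limit in this assay, > 200000 nM. Compound 3 `CCC(C)C1NC(=O)N(Cc2ccccc2)C1=O` also stops at a limit in this assay, > 200000 nM. Within the data shown here, the single measured step, a step that the two limits leave unreadable from compound 1 to compound 2, cannot be sized, since the limit of > 200000 nM in this assay, at which 3 of the 3 values shown sit, holds every value shown; compound 2 therefore stands at that limit and nowhere more exact. Compound 4 `O=C1NC(c2ccccc2)C(=O)N1C1CCCC1` differs from compound 2 by phenyl in place of isopropyl on a saturated ring carbon. Among the measured compounds shown here, no measured step touches a phenyl for isopropyl exchange, and the one step that exists is unreadable, so nothing in the data points to a change in this assay beyond the scatter in either direction. Compound 4 is therefore expected to show a step that the limit leaves unreadable from compound 2 to compound 4, most likely ending again at a limit. The estimate for compound 4 in this assay is 300000 nM, with a range from 60000 nM to 1500000 nM.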

Compound 4, half-maximal inhibitory concentration: > 200000 nM
Compound 4: no number, only a limit; the forecaster's own chance of this, stated with the estimate: 85%; the middle value does not contradict the limit.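

Compound 4 also gives only a limit, and the steps to it from compound 1 and compound 2 cannot be read, because all values stand at the same limit: the limit of > 200000 nM in this assay, at which 4 of the 4 values shown sit. The compounds shown leave open whether sec-butyl, isopropyl or phenyl on the shared core makes any difference in this assay.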